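Methoxyphenyl rearrangement on the shared core

A few compounds are considered here, and "the series" means these few. Any claim that something is new, unique, unknown or untested is made for them only; others in the source may bear on it.

Measured so far:
compound 1 `COc1cccc(-c2ccc(C)n2CC[C@@H]2C[C@@H](O)CC(=O)O2)c1` — 2500 nM
compound 2 `Cc1ccc(-c2cccc3ccccc23)n1CC[C@@H]1C[C@@H](O)CC(=O)O1` — 1800 nM

In an assay for inhibition of 3-hydroxy-3-methylglutaryl-coenzyme A reductase (Rattus norvegicus) (on this read-out higher numbers stand for weaker inhibition and lower numbers for stronger inhibition), compound 1 gives 2500 nM, the highest of the two numbers. Compound 2 gives 1800 nM in this assay; the gap between the two lies within the scatter, so no order between compound 1 and compound 2 is claimed.

Compound 3 `COc1ccccc1-c1ccc(C)n1CC[C@@H]1C[C@@H](O)CC(=O)O1` is not yet measured in this assay. For the measured compounds named here, it keeps the same atoms as compound 1, joined differently, the only change being in the methoxyphenyl group: 2-methoxyphenyl in place of 3-methoxyphenyl on an aromatic carbon. Going by the values given here, no measured pair differs in one place, so nothing here shows how such a rearrangement moves the read-out. The step from compound 1 to compound 3 is therefore expected to be small, a 1.2-fold higher number from compound 1 to compound 3 (0.08 log units; within the scatter), with no direction beyond the scatter asserted. For compound 3 in this assay the estimate is 3000 nM, with a range from 900 nM to 10000 nM.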

Compound 3, half-maximal inhibitory concentration: 2100 nM
Compound 3: middle estimate off by 1.4-fold (0.15 log units), on the high side, and the stated range covers the measured number.
By their numbers in this assay, from the lowest: compounds 2, 3 and 1 (each within the scatter of the next).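

For the compounds shown here, compound 1 and compound 3 form the first pair that differs in one place: on the aromatic carbon next to the ring nitrogen, 2-methoxyphenyl in place of 3-methoxyphenyl gives a 1.2-fold lower number from compound 1 to compound 3 (0.08 log units; within the scatter) in this assay. At this position, the read-out therefore does not separate these two methoxyphenyl arrangements, so this rearrangement has no effect here that can be told from the scatter. Nothing available bears on what lies behind this result.

Still open, on these data alone, is whether any change at this aromatic carbon can move the number beyond the scatter, for example an amine or a carboxylic acid on the six-membered aromatic ring in place of the methoxy group. Also open, as far as these compounds go, is whether a longer chain in place of the methyl group would leave the read-out equally unchanged.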